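Methyl for fluoro: a small change, a small expected step

The source may report more compounds than this note shows. Statements on the series, on what has been measured and on what is new or still open speak of the compounds shown alone.

Within the data shown here, compound 2 `CCOC(=O)N1CCC(=NNC(=O)c2ccc(F)cc2)CC1` is one of only two compounds measured in a functional assay for inhibition, read by spectrophotometry, with a stated time of 120 min; on this read-out lower numbers stand for stronger inhibition and higher numbers for weaker inhibition. In this assay compound 2 gives 65600 nM. Among the measured compounds shown here, the only other number comes from compound 1 `CCOC(=O)N1CCC(=NNC(=O)c2ccc(Cl)cc2)CC1`, which in this assay gives 72300 nM, and that value lies within the scatter of the value of compound 2; the two cannot be ranked. For the measured compounds named here, the one measured step, a 1.1-fold lower number from compound 1 to compound 2 (0.04 log units; within the scatter), shows fluoro in place of chloro on an aromatic carbon leaving the read-out essentially unchanged.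

Compound 3 `CCOC(=O)N1CCC(=NNC(=O)c2ccc(C)cc2)CC1` has not yet been measured. Its difference from compound 2 is methyl in place of fluoro on an aromatic carbon, at the same place on the same ring where the chloro-to-fluoro exchange sat. Going by the values given here, the single step that bears on it, a 1.1-fold lower number from compound 1 to compound 2 (0.04 log units; within the scatter), was within the scatter, so no step beyond the scatter is expected in this assay, in either direction. Compound 3 is therefore expected to give about 68000 nM in this assay, with a range from 30000 nM to 155000 nM. That estimate means an expected step of a 1.0-fold higher number from compound 2 to compound 3 (0.02 log units; within the scatter).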

Compound 3, half-maximal inhibitory concentration: 52500 nM
For compound 3 the middle estimate is 1.3-fold (0.11 log units) above the measured one, within the range that was stated.
By their numbers in this assay, from the lowest: compounds 3, 2 and 1 (each within the scatter of the next).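

In this assay, methyl in place of fluoro gives a 1.2-fold lower number from compound 2 to compound 3 (0.10 log units; within the scatter) and methyl in place of chloro gives a 1.4-fold lower number from compound 1 to compound 3 (0.14 log units; within the scatter) at the same place, on the aromatic carbon para to a large group. The earlier pair had compared only chloro with fluoro, whereas compound 3 shows that a carbon group at this place also leaves the read-out within the scatter of both, so the three compounds still cannot be ranked and this exchange, 4-fluorophenyl to 4-methylphenyl, opens no measurable gap. Nothing available explains why these three groups read alike.

As far as these compounds go, whether this place stays as flat with other groups remains open: an amine, a methoxy group, a carboxylic acid or a longer chain on the same ring could either stay within the scatter or move the number well beyond it. Also open, from the compounds shown here alone, is whether a change elsewhere in the shared core, such as at the ethyl ester end, would shift the read-out more than any exchange at this place has so far.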